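A few compounds are considered here, and "the series" means these few. Any claim that something is new, unique, unknown or untested is made for them only; others in the source may bear on it.

Working notes on the series. Within the data shown here, in an ADME assay on A549 cells (Homo sapiens) for cytotoxicity, read by MTT assay, with a stated time of 24 h (a higher number here means that more compound is needed for the effect, a lower number that less compound is needed), compound 2 `COCCOCCOCCOCC(=O)Oc1c(C(C)C)cccc1C(C)C` gives 740000 nM, the highest of the two numbers so far; its nearest neighbour is compound 1 `COCCOCCOCCOCCOCCOCCOCC(=O)Oc1c(C(C)C)cccc1C(C)C`, which gives 520000 nM in this assay. Among the measured compounds shown here, the one comparable step is a 1.4-fold higher number from compound 1 to compound 2 (0.15 log units; within the scatter), a change at the same place, running the opposite way. Compound 3 `COCCOCCOCCOCCOCCOCCOCCOCC(=O)Oc1c(C(C)C)cccc1C(C)C` carries a group of 12 heavy atoms (8 carbon, 4 oxygen; no ring) in place of a hydrogen atom, on a saturated chain carbon bound to an oxygen on a saturated carbon. For the measured compounds named here, since the only relevant step stayed within the scatter, no step beyond the scatter is expected in this assay, with the estimated change a 1.5-fold lower number from compound 2 to compound 3 (0.17 log units; within the scatter) at most a slight fall. Compound 3 is therefore estimated at 500000 nM, expected between 250000 nM and 1000000 nM.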

Compound 3, half-maximal effective concentration: 520000 nM
Compound 3: the middle estimate sits 1.0-fold (0.02 log units) below what was measured; the measured number falls inside the stated range.
By their numbers in this assay, from the lowest: compounds 1, 3 and 2 (each within the scatter of the next).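

In this assay, the group of 12 heavy atoms (8 carbon, 4 oxygen; no ring) on the saturated chain carbon bound to an oxygen on a saturated carbon gives a 1.4-fold lower number from compound 2 to compound 3 (0.15 log units; within the scatter), while methoxymethyl in place of hydrogen at the same place gives no change at the digits printed from compound 1 to compound 3 (within the scatter). Both steps lie within the scatter, so neither addition separates compounds 1, 2 and 3 in this read-out. Nothing available explains this result.

Going by these compounds, whether an amine or a carboxylic acid at the chain end, or a much longer chain, would produce a step beyond the scatter remains open.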